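Adding a Methoxy Group to an Acrylic Acid Indole Series

The compounds below may be only part of what the source reports. "The series", "measured", "known", "first", "only" and "open" are said of these compounds alone.

Measured compounds:
Compound 1, `O=C(O)/C(=C/c1c[nH]c2ccc(OCc3ccccc3)cc12)c1ccccc1` — 34700 nM
Compound 2, `CC(=O)n1cc(/C=C(/C(=O)O)c2ccccc2)c2cc(OCc3ccccc3)ccc21` — 26700 nM
Compound 3, `COc1ccc(/C(=C\c2cn(C(C)=O)c3ccc(OCc4ccccc4)cc23)C(=O)O)cc1OC` — 1050 nM

All three were tested in a functional assay on DU-145 cells (Homo sapiens) for cytotoxicity, read by MTT assay, with a stated time of 72 h; a higher number here means a weaker inhibitor, a lower number a stronger inhibitor. Compound 1 gives the highest number of the three, so it is the weakest inhibitor shown; compound 2 is closest to it, and the step of a 1.3-fold lower number from compound 1 to compound 2 (0.11 log units; within the scatter) lies within the scatter, so those two cannot be told apart. Compound 3 stands furthest away.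

The unmeasured compound 4, `COc1ccc(/C(=C\c2c[nH]c3ccc(OCc4ccccc4)cc23)C(=O)O)cc1`, differs from compound 1 in one place: methoxy in place of hydrogen on an aromatic carbon.

For the measured compounds named here, the only measured step touching this part of the shared core is a 25-fold lower number from compound 2 to compound 3 (1.41 log units; beyond the scatter), where the phenyl on the double-bonded chain carbon becomes 3,4-dimethoxyphenyl. Compound 4 carries a single methoxy rather than two, and keeps the hydrogen on the aromatic nitrogen that compound 1 has, so a drop of the same kind, but likely smaller, seems reasonable. On that basis compound 4 is expected to be a clearly stronger inhibitor than compound 1, with an estimated step of a 7.7-fold lower number from compound 1 to compound 4 (0.89 log units; beyond the scatter). The estimate for compound 4 is 4500 nM, with a range from 1500 nM to 15000 nM.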

Compound 4, half-maximal inhibitory concentration: 38100 nM
For compound 4 the middle estimate is 8.5-fold (0.93 log units) below the measured one; the whole stated range lies below it.
By their numbers in this assay, from the lowest: compound 3; then compounds 2, 1 and 4 (each within the scatter of the next).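

In this assay a single methoxy at this place, on an aromatic carbon para to a large group, has no effect that can be read: changing phenyl to 4-methoxyphenyl gives a 1.1-fold higher number from compound 1 to compound 4 (0.04 log units; within the scatter) and leaves the two compounds indistinguishable. The large 25-fold lower number from compound 2 to compound 3 (1.41 log units; beyond the scatter) that comes with 3,4-dimethoxyphenyl on the compound with an acetyl on the aromatic nitrogen therefore does not carry over to one methoxy on the core that keeps the hydrogen on that nitrogen, so the earlier step cannot be treated as a general gain from adding methoxy groups to this ring. Nothing measured here explains this difference between the two changes.

It remains open whether the large step depends on the second methoxy, on the acetyl, or on both together, since 4-methoxyphenyl with the acetyl and 3,4-dimethoxyphenyl with the nitrogen hydrogen are not among the compounds shown. Also open, going by these compounds, is how this ring carbon would respond to a different group in place of the methoxy, such as a hydroxyl, an amine or a longer ether chain.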